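The compounds below may be only part of what the source reports. "The series", "measured", "known", "first", "only" and "open" are said of these compounds alone.

Compound 1 `COc1cccc(NC(=S)Nc2cccc(C(F)(F)F)c2)c1`: 20000 nM
Compound 2 `Fc1ccc(NC(=S)Nc2cccc(C(F)(F)F)c2)cc1`: 40000 nM

In an ADME assay on Vero 76 cells (Chlorocebus sabaeus) for cytotoxicity, read by crystal violet staining, with a stated time of 96 h (a higher number here means that more compound is tolerated, a lower number that less compound is tolerated), compound 2 gives 40000 nM and compound 1 gives 20000 nM, two numbers within the scatter of each other. Compound 3 `FC(F)(F)c1cccc(NC(=S)Nc2cccc(Br)c2)c1` has not yet been measured. It has 3-bromophenyl in place of 4-fluorophenyl on an amide-type nitrogen. Going by the values given here, no measured step shows what such a swap does in this assay, so no change beyond the scatter is expected, and the expected step is a 1.6-fold lower number from compound 2 to compound 3 (0.20 log units; within the scatter). For compound 3 the estimated value is 25000 nM, with an expected range from 10000 nM to 60000 nM.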

Compound 3, half-maximal cytotoxic concentration: 14000 nM
The estimate for compound 3 lay 1.8-fold (0.25 log units) above the measured number; low and high end bracket the measured number.
By their numbers in this assay, from the lowest: compounds 3, 1 and 2 (each within the scatter of the next, the first and the last beyond it).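

In this assay the swap to 3-bromophenyl in place of 4-fluorophenyl on an amide-type nitrogen moves the number beyond the scatter (a 2.9-fold lower number from compound 2 to compound 3 (0.46 log units; beyond the scatter)), so a change at this place can lower the tolerated concentration. Bromo in place of methoxy on an aromatic carbon, by contrast, stays within the scatter (a 1.4-fold lower number from compound 1 to compound 3 (0.15 log units; within the scatter)). Nothing available explains either step.

Going by these compounds, the halogen and its place on the ring both differ in the first step, so the share of each stays open. On these data alone, how an amine or a carboxylic acid at this place would read is also open.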